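The compounds below may be only part of what the source reports. "The series", "measured", "known", "first", "only" and "open" are said of these compounds alone.

Measured compounds in a functional assay on UO-31 cells (Homo sapiens) for cytotoxicity, read by sulforhodamine B assay, with a stated time of 48 h, tested at 10 uM; on this read-out lower numbers stand for a stronger effect and higher numbers for a weaker effect at the one concentration tested: compound 1 `COc1cc(-c2cc(/C=C/C(=O)c3ccc(N)cc3)[nH]n2)cc(OC)c1OC` gives -84%; compound 2 `COc1ccc(-c2cc(/C=C/C(=O)c3ccc(OC)c(OC)c3)[nH]n2)cc1` gives -96%; compound 3 `COc1cc(-c2cc(/C=C/C(=O)c3ccc(Cl)c(Cl)c3)[nH]n2)cc(OC)c1OC` gives 40%.

Compound 1 stands second of the three; compound 2 lies beyond the scatter on the lower side, compound 3 far on the higher side. Among the compounds with values here, the only computed step, a number 124 percentage points higher from compound 1 to compound 3 (beyond the scatter), changes the aryl on the carbonyl carbon, not the ring altered here.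

Compound 4 `COc1ccc(-c2cc(/C=C/C(=O)c3ccc(N)cc3)[nH]n2)cc1OC` differs from compound 1 by hydrogen in place of methoxy on an aromatic carbon. Within the data shown here, no measured step bears on this change; compound 2, carrying fewer methoxy groups on that ring, shows a number of similar size to compound 1. Compound 4 is therefore expected to show no step beyond the scatter, a number 4 percentage points higher from compound 1 to compound 4 (within the scatter), with an estimate of -80% and a range from -100% to -40%.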

Compound 4, a percentage reported as activity, at one concentration (the size of the read-out at that concentration, not a potency): 11%
For compound 4 the middle estimate is 91 percentage points below the measured one; the measured number lies above the stated range.
By their numbers in this assay, from the lowest: compound 2; then compound 1; then compound 4; then compound 3.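

In this assay, replacing this methoxy with hydrogen gives a number 95 percentage points higher from compound 1 to compound 4 (beyond the scatter), a weaker effect at the one concentration tested. This methoxy, ortho to a methoxy group and meta to a large group, therefore counts, and the methoxy-bearing ring joins the aryl on the carbonyl carbon as a place where a single change moves the number. Nothing available explains this step.

Open, on these data alone, is whether hydroxy, ethoxy or an amine on this carbon would keep the number near that of compound 1. Also open, as far as these compounds go, is whether the same removal would matter with 3,4-dichlorophenyl on the carbonyl carbon.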